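Replacing 2-phenyl-1H-imidazol-1-yl with 1H-pyrazol-1-yl

This account rests on a few compounds, and the source may have more. Where it says the series, first, only, none or still open, it means among the compounds named here.

- compound 1 `CCC(C)n1ncn(-c2ccc(N3CCN(c4ccc(OC[C@@H]5CO[C@@](Cc6ccccc6)(c6ccc(Cl)cc6Cl)O5)cc4)CC3)cc2)c1=O`: 513 nM
- compound 2 `CCC(C)n1ncn(-c2ccc(N3CCN(c4ccc(OC[C@@H]5CO[C@@](CN6CCNCC6)(c6ccc(Cl)cc6Cl)O5)cc4)CC3)cc2)c1=O`: 608 nM
- compound 3 `CCC(C)n1ncn(-c2ccc(N3CCN(c4ccc(OC[C@@H]5CO[C@@](Cn6ccnc6-c6ccccc6)(c6ccc(Cl)cc6Cl)O5)cc4)CC3)cc2)c1=O`: 136 nM

In a functional assay on HUVEC cells (Homo sapiens), read by scintillation counting and thymidine incorporation, with a stated time of 24 h (a higher number here means a weaker inhibitor, a lower number a stronger inhibitor), compound 3 gives 136 nM, the lowest of the three numbers. Compound 4 `CCC(C)n1ncn(-c2ccc(N3CCN(c4ccc(OC[C@@H]5CO[C@@](Cn6cccn6)(c6ccc(Cl)cc6Cl)O5)cc4)CC3)cc2)c1=O` has not yet been measured. It differs from compound 3 as follows: 1H-pyrazol-1-yl in place of 2-phenyl-1H-imidazol-1-yl on a saturated chain carbon bound to a saturated ring carbon. The 1H-pyrazol-1-yl group stands in place of 2-phenyl-1H-imidazol-1-yl on a saturated chain carbon bound to a saturated ring carbon.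

For the measured compounds named here, two measured steps bear most directly on this change, both modest and beyond the scatter: a 3.8-fold lower number from compound 1 to compound 3 (0.58 log units; beyond the scatter), and a 4.5-fold lower number from compound 2 to compound 3 (0.65 log units; beyond the scatter). Each of them arrives at the 2-phenyl-1H-imidazol-1-yl group from another group. The remaining step, a 1.2-fold higher number from compound 1 to compound 2 (0.07 log units; within the scatter), stays within the scatter. Going by the values given here, no measured compound carries 1H-pyrazol-1-yl itself. Leaving 2-phenyl-1H-imidazol-1-yl is therefore expected to give a modest step towards a higher number in this assay, similar in size to those two steps. The expected step is a 2.9-fold higher number from compound 3 to compound 4 (0.47 log units; beyond the scatter). The estimate for compound 4 is 400 nM, with an expected range from 130 nM to 1100 nM.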

Compound 4, half-maximal inhibitory concentration: 307 nM
For compound 4 the middle estimate is 1.3-fold (0.11 log units) above the measured one; measured number inside the range.
By their numbers in this assay, from the lowest: compound 3; then compounds 4, 1 and 2 (each within the scatter of the next).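

In this assay, 1H-pyrazol-1-yl on the saturated chain carbon gives a 2.3-fold higher number from compound 3 to compound 4 (0.35 log units; beyond the scatter), so a five-membered aromatic ring with two hetero atoms does not by itself reproduce the number of compound 3. Against the other groups, a 2.0-fold lower number from compound 2 to compound 4 (0.30 log units; within the scatter) and a 1.7-fold lower number from compound 1 to compound 4 (0.22 log units; within the scatter) both stay within the scatter, which leaves phenyl, piperazin-1-yl and 1H-pyrazol-1-yl together at this place, with only compound 3 standing apart from all three. No available evidence accounts for these differences.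

As far as these compounds go, whether the lower number of compound 3 belongs to its phenyl ring or to its imidazole stays open, and an unsubstituted 1H-imidazol-1-yl or a phenyl-bearing pyrazole at this place would separate the two. From the compounds shown here alone, how a carboxylic acid or a longer chain would fare here is equally open.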